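Replacing phenyl with bromo on the core of compound 1

The source may hold more compounds than are shown below. What is called first, only, known or untested is meant among the compounds shown, and "the series" means these compounds.

Measured so far in an ADME assay on cells for inhibition of Fatty-acid amide hydrolase 1 (Homo sapiens), with stated times of 30 min and 15 min; on this read-out higher numbers stand for weaker inhibition and lower numbers for stronger inhibition:
Compound 1 `Cc1c(-c2ccccc2)cn(Cc2ccc(F)cc2)c(=O)c1C(=O)NC1CCCCCC1`: 70 nM
Compound 2 `COc1ccc(-c2cn(Cc3ccc(F)cc3)c(=O)c(C(=O)NC3CCCCCC3)c2C)cc1`: 1300 nM
Compound 3 `Cc1ccnc(OCc2ccc(F)cc2)c1C(=O)NC1CCCCCC1`: > 10000 nM, which is a limit of the assay and not a number.

For the measured compounds named here, compound 1 gives the lowest of the two numbers; the nearest, compound 2, sits a 19-fold higher number from compound 1 to compound 2 (1.27 log units; beyond the scatter), the only step measured in this set. Compound 4 `Cc1c(Br)cn(Cc2ccc(F)cc2)c(=O)c1C(=O)NC1CCCCCC1` differs from compound 1 in one place: bromo in place of phenyl on an aromatic carbon. Going by the values given here, no measured step removes the phenyl itself, but the step from compound 1 to compound 2 shows that this part of the core responds strongly to change, so a clear step in this assay is expected, towards weaker inhibition, a 5.0-fold higher number from compound 1 to compound 4 (0.70 log units; beyond the scatter). For compound 4 the expected value is 350 nM, within 70 nM to 2500 nM.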

Compound 4, half-maximal inhibitory concentration: 2300 nM
For compound 4 the middle estimate is 6.6-fold (0.82 log units) below the measured one; the range from low to high includes it.
By their numbers in this assay, from the lowest: compound 1; then compounds 2 and 4 (each within the scatter of the next). At a limit, above all of these: compound 3.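

In this assay, the phenyl of compound 1 cannot be exchanged for bromo without a large loss (a 33-fold higher number from compound 1 to compound 4 (1.52 log units; beyond the scatter)). The 4-methoxyphenyl of compound 2 and the bromo of compound 4 are not separated (a 1.8-fold higher number from compound 2 to compound 4 (0.25 log units; within the scatter)), so an aromatic ring at this position does not by itself keep the number of compound 1. Nothing shown gives a cause for these steps.

Open, as far as these compounds go, is whether an amine or a longer alkyl chain in place of the phenyl would come near compound 1. Also open, from the compounds shown here alone, is whether a hydroxyl or a chloro on the phenyl would be tolerated better than methoxy.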